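The source may hold more compounds than are shown below. What is called first, only, known or untested is meant among the compounds shown, and "the series" means these compounds.

Measured compounds in a functional assay on SN12C cells (Homo sapiens) for inhibition, read by sulforhodamine B assay, with a stated time of 48 h, tested at 10 uM; on this read-out higher numbers stand for a weaker effect at the one concentration tested and lower numbers for a stronger effect:
compound 1 `COc1cc2cc(Oc3ccc(NC(=O)Nc4ccc(C)cc4)cc3)c(C)nc2cc1OC` gives 93%
compound 2 `COc1cc2cc(Oc3ccc(NC(=O)Nc4cccc(C(F)(F)F)c4)cc3)c(C)nc2cc1OC` gives 17.2%

For the measured compounds named here, compound 1 holds the highest of the two numbers, hence the weaker effect of the pair, and the only step from it runs a number 75.8 percentage points lower from compound 1 to compound 2 (beyond the scatter). Compound 3 `COc1cc2cc(Oc3ccc(NC(=O)Nc4ccc(Cl)c(C(F)(F)F)c4)cc3)c(C)nc2cc1OC` is unmeasured; against compound 1 the change is 4-chloro-3-(trifluoromethyl)phenyl in place of 4-methylphenyl on an amide-type nitrogen. The step to 3-(trifluoromethyl)phenyl bears directly on this and was large and downward. A comparably large drop is therefore expected for compound 3, a number 78 percentage points lower from compound 1 to compound 3 (beyond the scatter), the added chlorine widening the uncertainty. Estimated for compound 3 in this assay: 15%, range 3% to 45%.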

Compound 3, a percentage reported as activity, at one concentration (the size of the read-out at that concentration, not a potency): 13.2%
The estimate for compound 3 lay 1.8 percentage points above the measured number; the measured number falls inside the stated range.
By their numbers in this assay, from the lowest: compounds 3 and 2 (each within the scatter of the next); then compound 1.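

In this assay, the 4-chloro-3-(trifluoromethyl)phenyl group on the amide-type nitrogen also gives a large change (a number 79.8 percentage points lower from compound 1 to compound 3 (beyond the scatter)), so this position tolerates a second substituent on that ring without loss of effect. Chloro in place of hydrogen on an aromatic carbon adds nothing that can be told from scatter (a number 4 percentage points lower from compound 2 to compound 3 (within the scatter)), which leaves the trifluoromethyl-bearing compound 2 and compound 3 level at this one concentration. Nothing measured here explains either step.

Still open, on these data alone, is whether chloro alone on this ring, without trifluoromethyl, gives a comparable effect. Also open, as far as these compounds go, is how an amine or a carboxylic acid in place of the trifluoromethyl would read.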